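The compounds below may be only part of what the source reports. "The series", "measured", "known", "first", "only" and "open" are said of these compounds alone.

Measured compounds:
compound 1, `COc1ccc(N(C)c2ncnc3c2ncn3C)cc1`: > 100000 nM
compound 2, `COc1ccc(N(C)c2nc(Cl)nc3c2ncn3C)cc1`: 2300 nM
compound 3, `COc1ccc(Cn2cnc3c(Cl)ncnc32)cc1OC`: > 50000 nM

Three compounds have been run in a functional assay on K562 cells (Homo sapiens) for antiproliferative activity, read by MTT assay, with a stated time of 48 h; a higher number here means a weaker inhibitor of growth, a lower number a stronger inhibitor of growth. Compound 1 sits at a limit of this assay, (the limit of > 100000 nM in this assay, at which 1 of the 3 values shown sits), and no number is given for it. Compound 2 gives 2300 nM in this assay. The change from compound 1 to compound 2 is chloro in place of hydrogen on an aromatic carbon, and it gives an at least 43-fold lower number from compound 1 to compound 2 (1.63 log units; beyond the scatter); the step can only be stated as a lower bound because compound 1 stands at the limit (the limit of > 100000 nM in this assay, at which 1 of the 3 values shown sits).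

Compound 3 also sits at a limit of this assay, (the limit of > 50000 nM in this assay, at which 1 of the 3 values shown sits), without a number. How the core of compound 3 differs from the core of compound 1 is not broken down here. The unmeasured compound 4, `COc1ccc(Cn2cnc3c(Cl)nc(Cl)nc32)cc1OC`, differs from compound 3 by chloro in place of hydrogen on an aromatic carbon. This is the same kind of change as that from compound 1 to compound 2, but not the same: around the place of entry it is meta to a chloro group (1 heavy atom), where in compound 1 the place is meta to a large group.

Among the compounds with values here, for compound 4 a step of an at least 5.0-fold lower number from compound 3 to compound 4 (0.69 log units; beyond the scatter) in this assay is expected, resting on the single measured step of an at least 43-fold lower number from compound 1 to compound 2 (1.63 log units; beyond the scatter) in a core whose relation to the core of compound 3 is not broken down. The estimate for compound 4 is 10000 nM, between 2000 nM and 50000 nM, and compound 3 itself having only a limit leaves the estimate loose.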

Compound 4, concentration for 50% growth inhibition: 7000 nM
Compound 4: the middle estimate sits 1.4-fold (0.15 log units) above what was measured; measured number inside the range.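

On the core of compound 3, chloro in place of hydrogen on an aromatic carbon gives an at least 7.1-fold lower number from compound 3 to compound 4 (0.85 log units; beyond the scatter) in this assay, the same direction as on the core of compound 1. The change therefore lowers the number on both cores shown, but each step is only a lower bound, and setting the two side by side fixes direction and not size: the same change on two cores in this assay, an at least 43-fold lower number (1.63 log units; beyond the scatter) from compound 1 to compound 2 and an at least 7.1-fold lower number (0.85 log units; beyond the scatter) from compound 3 to compound 4; the limit leaves it open whether they differ. Whether the change carries over with a similar size remains unsettled, and two pairs do not show that it would hold on any further core.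

The compounds shown leave open whether another group at the same place, between two ring nitrogen atoms, such as bromo, methoxy or an amine, would lower the number as chloro does, as only chloro and hydrogen appear there. Also open, as far as these compounds go, is what the remainder of each molecule contributes: compound 2 and compound 4 differ in more than one place, so these values do not separate the contribution of the two cores or of their aromatic substituents.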